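A few compounds are considered here, and "the series" means these few. Any claim that something is new, unique, unknown or untested is made for them only; others in the source may bear on it.

Measured so far in an assay on isolated protein for inhibition of serine/threonine-protein kinase 10 (Homo sapiens), read by thermal shift assay, tested at 10 uM; on this read-out lower numbers stand for weaker stabilisation of the target and higher numbers for stronger stabilisation of the target against heat:

compound 1 `Cc1ccc(S(=O)(=O)NC(=O)Nc2cc(C(C)(C)C)nn2-c2ccccc2)cc1` gives -0.9 degrees C

compound 2 `Cc1ccc(-n2nc(C(C)(C)C)cc2NC(=O)Nc2cc(F)cc(F)c2)cc1` gives 0.6 degrees C

Of these two numbers, compound 2 holds the higher one; compound 1 sits lower by more than the usual scatter of repeated measurements. No single-point change links the two, so nothing further is read into their gap.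

Compound 3 `CC(C)(C)c1cc(NC(=O)Nc2cc(F)cc(F)c2)n(-c2ccc(Br)cc2)n1` has not yet been measured. It differs from compound 2 in one place: bromo in place of methyl on an aromatic carbon. The group that leaves and the group that enters are each a single heavy atom sitting on the same carbon of the same ring, and nothing in the measured pair shows how such an exchange plays out in this assay.

The expected step from compound 2 to compound 3, a number 0.20 degrees C higher from compound 2 to compound 3 (within the scatter), is small and lies within the scatter, in no firm direction. Compound 3 is therefore estimated at 0.8 degrees C, with a range from -0.7 degrees C to 2.3 degrees C.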

Compound 3, shift of the target's melting temperature: 0.2 degrees C
Beside the measured number, compound 3's estimate is 0.60 degrees C above it, and the stated range covers the measured number.
By their numbers in this assay, from the lowest: compound 1; then compounds 3 and 2 (each within the scatter of the next).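

In this assay, replacing methyl with bromo on the aromatic carbon, which turns 4-methylphenyl into 4-bromophenyl, gives a number 0.40 degrees C lower from compound 2 to compound 3 (within the scatter). Among these compounds, this is the first exchange here that can be read at a single place, and it shows that the assay does not separate these two single-atom groups at this position of the shared core. So, on this evidence, either group can occupy this position without a shift that stands clear of the usual scatter, and no measurement at hand offers an explanation for the result.

Going by these compounds, whether an amine, a carboxylic acid or a longer chain at the same carbon would give a step beyond the scatter remains open. So does whether the same exchange of methyl for bromo would read the same way on a different core.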